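A few compounds are considered here, and "the series" means these few. Any claim that something is new, unique, unknown or untested is made for them only; others in the source may bear on it.

Working notes on the sulfoxide series.

Compound 1 `CC[S+]([O-])c1ccccc1` is one of a small set of sulfoxides tested in an assay for inhibition of alcohol dehydrogenase (Equus caballus); a higher number here means a weaker inhibitor, a lower number a stronger inhibitor. In this assay compound 1 gives 12500000 nM, the highest of the two single numbers in hand. Compound 2 `C[S+]([O-])Cc1ccccc1` gives 5000000 nM, a lower number than that of compound 1, with a gap beyond the usual scatter. Compound 3 `[O-][S+]1CC[S+]([O-])CC1` carries two sulfoxide groups on one ring and has two entries, 140000000 nM; 41000000 nM (2 entries); the spread between them the several entries of compound 3 in this assay, 140000000 nM; 41000000 nM (2 entries) shows how widely repeat numbers at this end of the range can fall, so the entries are not read as a single value.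

Compound 4 `C=C[S+]([O-])c1ccccc1` is not yet measured. It differs from compound 1 by vinyl in place of ethyl on a sulfur, in words vinyl in place of ethyl on a sulfur. Within the data shown here, no step between two measured compounds of this kind exists in the set, so the expectation rests on compound 1 alone. The change is small and is expected to move the number little, if at all, beyond the scatter; the step of a 1.3-fold lower number from compound 1 to compound 4 (0.10 log units; within the scatter) from compound 1 to compound 4 is estimated as close to none. Compound 4 is thus expected to give about 10000000 nM, within a range from 3000000 nM to 40000000 nM.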

Compound 4, inhibition constant: 500000 nM
The estimate for compound 4 lay 20-fold (1.30 log units) above the measured number, outside the stated range (below it).
By their numbers in this assay, from the lowest: compound 4; then compound 2; then compound 1.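

In this assay, the place on a sulfur whose other neighbours are aromatic carbon and oxygen proves sensitive: vinyl in place of ethyl gives a 25-fold lower number from compound 1 to compound 4 (1.40 log units; beyond the scatter). The two groups have the same count of heavy atoms and differ by one double bond outside aromatic rings, so a change that small in the counted features goes with a large step at this place. This remains a single pair, and one entry on each side should be read with care, as repeat numbers in this series can fall far apart: the several entries of compound 3 in this assay, 140000000 nM; 41000000 nM (2 entries)

The compounds shown leave open whether a propyl group or an ethynyl group at this place would follow ethyl or vinyl. No cause for the step can be read from these numbers.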